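The compounds below may be only part of what the source reports. "The series", "measured", "known", "first", "only" and "open" are said of these compounds alone.

Compound 3 `CSc1cccc2c(=O)c(-c3nn[nH]n3)c[nH]c12` belongs to a small set built on the shared core, differing only in the group carried on one aromatic carbon. In a functional assay on the whole organism (strain Sprague-Dawley) for inhibition, with Rattus norvegicus as the target (on this read-out lower numbers stand for an effect already at smaller amounts and higher numbers for an effect only at larger amounts of compound), compound 3 gives 10 mg/kg, the highest of the two numbers seen. Compound 2 `O=c1c(-c2nn[nH]n2)c[nH]c2c(C(F)(F)F)cccc12` gives 0.156 mg/kg, so there is a 64-fold higher number from compound 2 to compound 3 (1.81 log units; beyond the scatter). Compound 1 `O=c1c(-c2nn[nH]n2)c[nH]c2c(Br)cccc12` gives > 5 mg/kg, which is a limit of the assay rather than a number, as the limit of > 5 mg/kg in this assay, at which 1 of the 3 values shown sits, records. Hence there is a step that the limit leaves unreadable from compound 1 to compound 3. Compound 4 `CS(=O)(=O)c1cccc2c(=O)c(-c3nn[nH]n3)c[nH]c12` carries methylsulfonyl in place of methylsulfanyl on an aromatic carbon. Going by the values given here, no measured step exchanges these two particular groups, so only a loose expectation is possible. The expected change is a 3.3-fold lower number from compound 3 to compound 4 (0.52 log units; beyond the scatter). Compound 4 is therefore estimated at 3 mg/kg, within 0.5 mg/kg to 20 mg/kg.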

Compound 4, minimum effective dose: 10 mg/kg
For compound 4 the middle estimate is 3.3-fold (0.52 log units) below the measured one; the measured number falls inside the stated range.
By their numbers in this assay, from the lowest: compound 2; then compounds 3 and 4 (each within the scatter of the next).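

In this assay, putting methylsulfonyl in place of methylsulfanyl on this aromatic carbon leaves the reading where it was, with no change at the digits printed from compound 3 to compound 4 (within the scatter). Adding the two oxygens therefore does not close the gap to trifluoromethyl, as there is a 64-fold higher number from compound 2 to compound 4 (1.81 log units; beyond the scatter). Compound 1 has only a limit of the assay, so its steps cannot be read: the limit of > 5 mg/kg in this assay, at which 1 of the 4 values shown sits.

From the compounds shown here alone, it remains open whether an amine or a methoxy group on this carbon would give a number as low as that of compound 2. Going by these compounds, it also remains open whether any other group would.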